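The compounds below may be only part of what the source reports. "The series", "measured", "known", "first", "only" and "open" are said of these compounds alone.

Measured in an ADME assay on BCBL1 cells (Homo sapiens) for cytotoxicity, with a stated time of 7 days; on this read-out higher numbers stand for lower toxicity in this test and lower numbers for higher toxicity in this test:
Compound 1, `C=CCOc1nc(N)nc2c1ncn2/C=C1/CC1(CO)CO`, reaches only the limit > 20000 nM.
Compound 2, `COCCOc1nc(N)nc2c1ncn2/C=C1/CC1(CO)CO`, reaches only the limit > 20000 nM.
Compound 3, `Nc1nc(N2CCCC2)c2ncn(/C=C3/CC3(CO)CO)c2n1`, reaches only the limit > 20000 nM.

Compound 1 thus stands at the limit of > 20000 nM in this assay, at which 3 of the 3 values shown sit, and has no number of its own. Compound 4, `CC(C)CNc1nc(N)nc2c1ncn2/C=C1/CC1(CO)CO`, differs from it in one place: isobutylamino in place of allyloxy on an aromatic carbon. Among the measured compounds shown here, the steps that bear on this change are a step that the two limits leave unreadable from compound 1 to compound 2 and a step that the two limits leave unreadable from compound 1 to compound 3, each running from compound 1 to another limit. Since every measured value sits at the limit of > 20000 nM in this assay, at which 3 of the 3 values shown sit, no size can be read for the expected step in this assay, in either direction. Compound 4 is expected to sit at the limit too, with an estimated step that the limit leaves unreadable from compound 1 to compound 4. Compound 4 is estimated at 25000 nM, ranging from 10000 nM to 60000 nM.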

Compound 4, half-maximal cytotoxic concentration: > 20000 nM
Compound 4: a limit, no number; the forecaster's own chance of this, stated with the estimate: 80%; the middle value lies beyond the limit too.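

In this assay compound 4 gives > 20000 nM as a limit and not a number. Among the compounds shown here, no step between compound 4 and compound 1, compound 2 or compound 3 can be read: the limit of > 20000 nM in this assay, at which 4 of the 4 values shown sit. The compounds shown leave open at what concentration any of them becomes cytotoxic and how far apart they lie.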